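The source may hold more compounds than are shown below. What is called first, only, known or untested is meant among the compounds shown, and "the series" means these compounds.

Compound 1 `O=C1OC(c2cnc3ccccc3c2)CN1C1CCN(Cc2cc3ccccc3[nH]2)CC1`: in an in vitro functional assay on RBL cells for antagonist activity at C-C chemokine receptor type 8 (Homo sapiens), read by FLIPR and calcium flux (a lower number here means a stronger inhibitor, a higher number a weaker inhibitor), compound 1 gives < 50200 nM, which is a limit of the assay.
Compound 2 `O=C1OC(c2ccc3ccccc3n2)CN1C1CCN(Cc2cc3ccccc3[nH]2)CC1`: in this assay compound 2 gives < 50200 nM, again a limit of the assay.
Compound 3 `COc1ccc2nccc(C3CN(C4CCN(Cc5cc6ccccc6o5)CC4)C(=O)O3)c2c1`: in this assay compound 3 gives 1260 nM.

For the measured compounds named here, compound 3 thus holds the only number among the three; the other two values are limits, and the step that the two limits leave unreadable from compound 1 to compound 2 cannot be read from them (the limit of < 50200 nM in this assay, at which 2 of the 3 values shown sit). Compound 4 `COc1ccc2nccc(C3CN(C4CCN(CCCc5ccccc5)CC4)C(=O)O3)c2c1` differs from compound 3 in one place: phenethyl in place of 1-benzofuran-2-yl on a saturated chain carbon bound to an amine nitrogen in a ring. No measured step touches this part of the molecule, so nothing shown bears directly on the change. The expectation for compound 4 therefore rests on compound 3 alone, and the expected step of a 2.0-fold higher number from compound 3 to compound 4 (0.30 log units; within the scatter) in this assay is small and uncertain in direction. Compound 4 is estimated at 2500 nM, within a range from 600 nM to 15000 nM.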

Compound 4, half-maximal inhibitory concentration: 251 nM
Beside the measured number, compound 4's estimate is 10-fold (1.00 log units) above it, and the stated range ends above it.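

For the compounds shown here, the step at this position is the first readable one that involves the group on the saturated chain carbon bound to an amine nitrogen in a ring: phenethyl in place of 1-benzofuran-2-yl gives a 5.0-fold lower number from compound 3 to compound 4 (0.70 log units; beyond the scatter) in this assay. A lower number means a stronger inhibitor, so for this pair the fused ring with its oxygen is not needed for activity. Nothing measured here explains the gain. The change swaps ring and chain together, and the compounds shown do not separate the two. As far as these compounds go, how a longer chain or a pyridine ring in place of the phenyl would fare also remains open.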